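Extending an alkyl chain on a shared core

This account rests on a few compounds, and the source may have more. Where it says the series, first, only, none or still open, it means among the compounds named here.

Compound 2, `CCc1nc2nc(-c3ccccc3)cc(C(F)(F)F)c2c(=O)n1Cc1cn(CCC(F)(F)C(F)(F)C(F)(F)C(F)(F)C(F)(F)C(F)(F)F)nn1`, stands at the edge of what a functional assay on U-937 cells (Homo sapiens) for cytotoxicity, read by MTT assay, with a stated time of 24 h (a higher number here means a weaker inhibitor, a lower number a stronger inhibitor), can report. In this assay compound 2 gives only a limit, > 200 ug/mL. Its two neighbours are read the same way. Compound 1, `Cc1nc2nc(-c3ccccc3)cc(C(F)(F)F)c2c(=O)n1Cc1cn(CCC(F)(F)C(F)(F)C(F)(F)C(F)(F)C(F)(F)C(F)(F)F)nn1`, carries hydrogen where compound 2 carries methyl on the saturated chain carbon bound to an aromatic carbon. In this assay compound 1 also gives only a limit, > 200 ug/mL. Compound 3, `CCc1nc2nc(-c3ccccc3)cc(C(F)(F)F)c2c(=O)n1Cc1cn(CCC(F)(F)C(F)(F)C(F)(F)C(F)(F)C(F)(F)C(F)(F)C(F)(F)C(F)(F)F)nn1`, carries the longer fluorinated chain. In this assay compound 3 gives only a limit as well, > 200 ug/mL. The two measured steps, a step that the two limits leave unreadable from compound 1 to compound 2 and a step that the two limits leave unreadable from compound 2 to compound 3, therefore cannot be sized, because every value sits at the limit of > 200 ug/mL in this assay, at which 3 of the 3 values shown sit.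

Compound 4, `CCCCCCc1nc2nc(-c3ccccc3)cc(C(F)(F)F)c2c(=O)n1Cc1cn(CCC(F)(F)C(F)(F)C(F)(F)C(F)(F)C(F)(F)C(F)(F)F)nn1`, differs from compound 2 by butyl in place of hydrogen on a saturated chain carbon, two bonds along the chain from an aromatic carbon. The nearest measured step, a step that the two limits leave unreadable from compound 1 to compound 2, lengthened the same chain by a single carbon without any readable effect, and a step that the two limits leave unreadable from compound 2 to compound 3 was equally unreadable. Within the data shown here, no measured step gives a direction, so the expected step that the limit leaves unreadable from compound 2 to compound 4 is none beyond the scatter. Compound 4 is therefore expected to give about 300 ug/mL in this assay, within 120 ug/mL to 1000 ug/mL, most probably again reported only as a limit.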

Compound 4, half-maximal inhibitory concentration: 7.56 ug/mL
Beside the measured number, compound 4's estimate is 40-fold (1.60 log units) above it, and the stated range ends above it.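

In this assay, the alkyl chain at this position turns out to matter: butyl in place of hydrogen on a saturated chain carbon, two bonds along the chain from an aromatic carbon, gives an at least 26-fold lower number from compound 2 to compound 4 (1.42 log units; beyond the scatter). Measured from the shorter chain, the change to the hexyl chain gives an at least 26-fold lower number from compound 1 to compound 4 (1.42 log units; beyond the scatter), so among these compounds the hexyl chain of compound 4 produces a large effect on the cells where methyl and ethyl gave no readable one. The earlier steps shown here could not reveal this, because they could not be sized: the limit of > 200 ug/mL in this assay, at which 3 of the 4 values shown sit.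

Both new steps are minimum sizes rather than exact ones, and the compounds shown do not tell at what chain length between ethyl and hexyl the drop in the number sets in. They also leave open what a propyl or butyl chain, a chain longer than hexyl such as octyl, or an amine at the end of the hexyl chain would do at this position.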